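Capping the hydroxy group of compound 3

A few compounds are considered here, and "the series" means these few. Any claim that something is new, unique, unknown or untested is made for them only; others in the source may bear on it.

In a functional assay on KB cells (Homo sapiens) for antiproliferative activity, read by sulforhodamine B assay, with a stated time of 3 days (a lower number here means that less compound is needed, a higher number that more compound is needed for the effect), compound 1 `CCC1=C(O)c2c(oc(-c3ccc(CC(C)C)cc3)cc2=O)C(CC)(CC)C1=O` gives 29.3 uM, compound 2 `CCC1=C(O)c2c(oc(-c3ccc(C(F)(F)F)cc3)cc2=O)C(CC)(CC)C1=O` gives 35.7 uM and compound 3 `CCC1=C(O)c2c(oc(-c3ccc(O)cc3)cc2=O)C(CC)(CC)C1=O` gives 20.6 uM, so compound 3 stands within the scatter of both others. Compound 4 `CCC1=C(O)c2c(oc(-c3ccc(OC)cc3)cc2=O)C(CC)(CC)C1=O` carries the change methyl in place of hydrogen on an oxygen on an aromatic ring, turning hydroxy into methoxy. The nearest evidence is a 1.4-fold lower number from compound 1 to compound 3 (0.15 log units; within the scatter) and a 1.7-fold lower number from compound 2 to compound 3 (0.24 log units; within the scatter). Both lie within the scatter, though each swaps the whole group rather than that hydrogen alone. On those two steps, no change beyond the scatter is expected in this assay, and the estimated step is a 1.2-fold higher number from compound 3 to compound 4 (0.08 log units; within the scatter). For compound 4 the estimated value is 25 uM, with an expected range of 12 uM to 50 uM.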

Compound 4, concentration for half-maximal effect: 17.7 uM
For compound 4 the middle estimate is 1.4-fold (0.15 log units) above the measured one, and the stated range covers the measured number.
By their numbers in this assay, from the lowest: compounds 4, 3, 1 and 2 (each within the scatter of the next).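

Methyl in place of hydrogen on this oxygen is the first change shown that leaves the rest of the group in place, and in this assay it gives a 1.2-fold lower number from compound 3 to compound 4 (0.07 log units; within the scatter), a step within the scatter. The whole-group swaps give a 1.7-fold lower number from compound 1 to compound 4 (0.22 log units; within the scatter) and a 2.0-fold lower number from compound 2 to compound 4 (0.30 log units; within the scatter), so all four groups shown at this place lie within the scatter of one another. No measurement shown here accounts for this result. As far as these compounds go, whether an amine or carboxylic acid on this aromatic carbon, or a longer chain on the oxygen, would move the number beyond the scatter stays open.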